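A few compounds are considered here, and "the series" means these few. Any claim that something is new, unique, unknown or untested is made for them only; others in the source may bear on it.

Measured compounds in a functional assay on LOX cells (Homo sapiens) for antiproliferative activity, read by WST assay, with a stated time of 3 days; a higher number here means a weaker inhibitor, a lower number a stronger inhibitor:
Compound 1 `O=Cc1cc(=O)[nH]c(=O)n1[C@@H]1O[C@H](CO)[C@@H](O)[C@H]1O`: > 50000 nM (a limit)
Compound 2 `Nc1c(F)c(=O)[nH]c(=O)n1[C@@H]1O[C@H](CO)[C@@H](O)[C@H]1O`: 3400 nM

Only two results exist so far in this assay, and only one of them is a true number. Compound 1 reached just a limit, > 50000 nM, and no exact figure was obtained for it. For the measured compounds named here, compound 2, at 3400 nM, therefore holds the only numerical value, so its standing rests on this single reading.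

The next compound, compound 3 `O=Cc1c(F)c(=O)[nH]c(=O)n1[C@@H]1O[C@H](CO)[C@@H](O)[C@H]1O`, has formyl in place of amino on an aromatic carbon, ortho to a fluoro group: formyl in place of amino on an aromatic carbon. Going by the values given here, no measured step isolates this exchange. Formyl is also present in compound 1, whose result of > 50000 nM is a limit. The expectation is therefore a clear loss of strength rather than no change, though this rests on very little data. The expected move is a 4.4-fold higher number from compound 2 to compound 3 (0.64 log units; beyond the scatter), towards weaker inhibition. For compound 3 the estimated value is 15000 nM, with an expected range from 3000 nM to 50000 nM.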

Compound 3, half-maximal inhibitory concentration: 400 nM
Compound 3: the middle estimate sits 38-fold (1.57 log units) above what was measured, outside the stated range (below it).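

In this assay, formyl in place of amino on an aromatic carbon, ortho to a fluoro group, gives an 8.5-fold lower number from compound 2 to compound 3 (0.93 log units; beyond the scatter), so with the fluoro group present this position tolerates formyl and the number improves with it, something compound 1 alone could not reveal. Fluoro in place of hydrogen on an aromatic carbon, with formyl kept, gives an at least 120-fold lower number from compound 1 to compound 3 (2.09 log units; beyond the scatter), so among these compounds formyl yields a measurable value only alongside the fluoro group. The true size of that step stays open because compound 1 stands at a limit and not at a number: the limit of > 50000 nM in this assay, at which 1 of the 3 values shown sits.

The compounds shown cannot say whether the gain belongs to formyl specifically, and an acetyl group, a hydroxymethyl group or a carboxylic acid in the same place would help separate that from a more general carbonyl effect on the number. They also leave open whether chlorine or a methyl group could stand in for the fluoro group, and how amino behaves with hydrogen in its neighbouring place, so the effect of fluoro is known only for the formyl pair.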